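This account rests on a few compounds, and the source may have more. Where it says the series, first, only, none or still open, it means among the compounds named here.

Compound 3 `CC1=NN(c2ccccc2)C(=O)C12C=CC(=O)C=C2c1ccc(C)cc1` is the reference point here. In a functional assay on A549 cells (Homo sapiens) for antiproliferative activity, read by CCK-8 assay, with a stated time of 72 h (on this read-out higher numbers stand for weaker inhibition and lower numbers for stronger inhibition), compound 3 gives 19300 nM, the lowest of the two numbers measured. Its closest neighbour is compound 2 `CC1=NN(c2ccc(Cl)cc2)C(=O)C12C=CC(=O)C=C2c1ccc(C)cc1`, which in this assay gives 33400 nM. The step between them, a 1.7-fold lower number from compound 2 to compound 3 (0.24 log units; within the scatter), is a hydrogen in place of a chloro on an aromatic carbon and lies within the scatter. Compound 1 `CC1=NN(c2ccc(Br)cc2)C(=O)C12C=CC(=O)C=C2c1ccccc1` carries a bromo on the same ring but lacks the methyl on the other ring; in this assay compound 1 reaches only a limit, > 100000 nM, so no number is known for it (the limit of > 100000 nM in this assay, at which 1 of the 3 values shown sits).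

Compound 4 `CC1=NN(c2ccc(Br)cc2)C(=O)C12C=CC(=O)C=C2c1ccc(C)cc1` has not yet been measured. It differs from compound 3 by bromo in place of hydrogen on an aromatic carbon. Among the compounds with values here, the only measured step that bears on this is the chloro-to-hydrogen change from compound 2 to compound 3, which moved the number by an amount inside the scatter. A bromo entering the same place is expected to behave much like the chloro did, so the step from compound 3 to compound 4 in this assay is expected to be small and upward, at most around a 1.6-fold higher number from compound 3 to compound 4 (0.19 log units; within the scatter). Compound 4 is therefore estimated to give 30000 nM, with a plausible range from 12000 nM to 80000 nM.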

Compound 4, half-maximal inhibitory concentration: 27400 nM
Estimate against measurement, compound 4: 1.1-fold (0.04 log units) above, within the range that was stated.
By their numbers in this assay, from the lowest: compounds 3, 4 and 2 (each within the scatter of the next). At a limit, above all of these: compound 1.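

In this assay, the aromatic carbon para to a large group now has three occupants to compare: bromo in place of hydrogen gives a 1.4-fold higher number from compound 3 to compound 4 (0.15 log units; within the scatter), and bromo in place of chloro gives a 1.2-fold lower number from compound 2 to compound 4 (0.09 log units; within the scatter), so hydrogen, chloro and bromo at this place cannot be told apart in this assay. Compound 4 also completes a pair that differs only by methyl in place of hydrogen on the other aromatic ring, and that change gives an at least 3.6-fold lower number from compound 1 to compound 4 (0.56 log units; beyond the scatter), the one step among these new comparisons that lies beyond the scatter. Compound 1 stands at a limit and not at a number, so this step has only a lower bound and its true size stays unknown: the limit of > 100000 nM in this assay, at which 1 of the 4 values shown sits.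

The compounds shown leave open whether a methoxy group, an amine or a carboxylic acid at the para place of the phenyl ring would move the number beyond the scatter. They also leave open whether a longer chain such as ethyl in place of the methyl would lower the number further, and whether the methyl step holds with hydrogen or chloro in place of the bromo.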